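Compound 3 and one added methoxy

This account rests on a few compounds, and the source may have more. Where it says the series, first, only, none or still open, it means among the compounds named here.

In a functional assay on SW480 cells (Homo sapiens) for antiproliferative activity, read by sulforhodamine B assay, with a stated time of 48 h (a higher number here means a weaker inhibitor, a lower number a stronger inhibitor), three compounds on a shared core have numbers. Compound 1 (`COc1cc(C=C(C(=O)/C=C/c2cccc(OC)c2OC)C(=O)/C=C/c2cccc(OC)c2OC)cc(Br)c1O`) reads 260 nM and compound 2 (`COc1ccc(OC)c(/C=C/C(=O)C(=Cc2ccc(O)c(F)c2)C(=O)/C=C/c2cc(OC)ccc2OC)c1`) reads 510 nM while compound 3 (`COc1ccc(/C=C/C(=O)C(=Cc2ccc(O)c(OC)c2)C(=O)/C=C/c2ccc(OC)cc2OC)c(OC)c1`) reads 1520 nM as the highest number of the three. Compound 3 is the weakest of these, beyond the scatter from both others, with compound 2 nearest and compound 1 furthest.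

Compound 4 (`COc1ccc(/C=C/C(=O)C(=Cc2cc(OC)c(O)c(OC)c2)C(=O)/C=C/c2ccc(OC)cc2OC)c(OC)c1`) differs from compound 3 by one change (methoxy in place of hydrogen on an aromatic carbon): methoxy in place of hydrogen on an aromatic carbon, ortho to a hydroxy group, turning 4-hydroxy-3-methoxyphenyl into 4-hydroxy-3,5-dimethoxyphenyl. Among the compounds with values here, no measured pair shows this change alone, so its size remains open. In this assay a small step towards a lower number, not clearly beyond the scatter, is expected. Within the data shown here, the only ground is that compound 3 at 1520 nM sits highest of the three. The expected step is a 1.7-fold lower number from compound 3 to compound 4 (0.23 log units; within the scatter) and rests on thin evidence. For compound 4 the estimate is 900 nM with a range from 350 nM to 2200 nM in this assay.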

Compound 4, half-maximal inhibitory concentration: 850 nM
The estimate for compound 4 lay 1.1-fold (0.02 log units) above the measured number, within the range that was stated.
By their numbers in this assay, from the lowest: compounds 1, 2, 4 and 3 (each within the scatter of the next, the first and the last beyond it).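

In this assay, within the data shown here, this pair gives the first reading of a single change, a 1.8-fold lower number from compound 3 to compound 4 (0.25 log units; within the scatter), for methoxy in place of hydrogen on an aromatic carbon, ortho to a hydroxy group. Going from 4-hydroxy-3-methoxyphenyl to 4-hydroxy-3,5-dimethoxyphenyl therefore leaves the number within the scatter, so this position carries the added methoxy without a clear shift in either direction. No measurement on these compounds offers an explanation for this step.

Still open, going by these compounds, is how an amine or a carboxylic acid would read on this same aromatic carbon. Also open, on these data alone, is whether the added methoxy reads the same when the methoxy groups on the two outer aromatic rings are arranged as in compound 1 or compound 2.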